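Masking the Acid of Compound 2 as an Ester

The source may report more compounds than this note shows. Statements on the series, on what has been measured and on what is new or still open speak of the compounds shown alone.

Compound 2 `Nc1ccc(-c2cc(=O)c3c(N)c(F)c(C(=O)O)c(F)c3o2)cc1F` carries a free carboxy group on its core. In a functional assay on MCF7 cells (Homo sapiens) for cytotoxicity, read by neutral red uptake, with a stated time of 3 days (on this read-out higher numbers stand for weaker inhibition and lower numbers for stronger inhibition), compound 2 reaches only > 10000 nM, which is a limit of the assay and not a number; this is the limit of > 10000 nM in this assay, at which 1 of the 2 values shown sits. Its closest measured relative is compound 1 `CCOC(=O)c1c(F)c(N)c2c(=O)cc(-c3ccc(N)c(F)c3)oc2c1F`, the ethyl ester of the same acid, and in this assay compound 1 gives 1400 nM. For the measured compounds named here, the one step that joins the two, an at least 7.1-fold higher number from compound 1 to compound 2 (0.85 log units; beyond the scatter), is a loss of activity on uncovering the acid.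

Compound 3 `CCCCCC(=O)OCc1c(F)c(N)c2c(=O)cc(-c3ccc(N)c(F)c3)oc2c1F` is the unmeasured member: ((pentylcarbonyl)oxy)methyl in place of carboxy on an aromatic carbon. This change once more hides the carboxy group behind an ester, as in compound 1, only with a larger group. Going by the values given here, the single measured step that bears on it, an at least 7.1-fold higher number from compound 1 to compound 2 (0.85 log units; beyond the scatter), ran the other way, so the movement from compound 2 to compound 3 is expected to be a fall in the number, back toward what compound 1 shows with 1400 nM. The expected step is an at least 6.6-fold lower number from compound 2 to compound 3 (0.82 log units; beyond the scatter). For compound 3 the estimate in this assay is 1500 nM, with a range from 500 nM to 5000 nM.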

Compound 3, half-maximal inhibitory concentration: 160 nM
Beside the measured number, compound 3's estimate is 9.4-fold (0.97 log units) above it; measured number outside the range, below it.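

In this assay, the aromatic carbon ortho to two fluoro groups carries ((pentylcarbonyl)oxy)methyl in place of carboxy, and this change gives an at least 62-fold lower number from compound 2 to compound 3 (1.79 log units; beyond the scatter), so the large step sets only a lower bound on the gain. Compound 2 stands at a limit of the assay and not a number: the limit of > 10000 nM in this assay, at which 1 of the 3 values shown sits. The earlier pair showed only that the ethyl ester outperforms the free acid, whereas the new comparison separates two ester-bearing groups at this carbon, with an 8.8-fold lower number from compound 1 to compound 3 (0.94 log units; beyond the scatter), so the ethyl ester of compound 1 does not mark the best that this position allows.

Compounds 1 and 3 differ in chain length and also in how the ester is attached, since the carbonyl of compound 3 lies farther out, behind an oxygen and a methyl, and these compounds alone cannot say which of the two features carries the step. As far as these compounds go, a hydroxymethyl group or an acetyloxymethyl group at this carbon would bear on that question, and whether compound 3 acts intact in these cells remains open as well.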